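Volume of distribution across sulfonyl aryl variants of the shared core

This account rests on a few compounds, and the source may have more. Where it says the series, first, only, none or still open, it means among the compounds named here.

Measured so far in an ADME assay on the whole organism (Rattus norvegicus, strain Sprague-Dawley) for pharmacokinetics, read by LC-MS, with a stated time of 30 min; on this read-out lower numbers stand for narrower distribution and higher numbers for wider distribution into tissues:
- compound 1, `N#Cc1ccc(O[C@H]2CN(S(=O)(=O)c3ccc(Cl)cc3)C[C@@]2(O)CO)cc1F`: 6 L/kg
- compound 2, `N#Cc1ccc(O[C@H]2CN(S(=O)(=O)c3ccc(C(F)(F)F)nc3)C[C@@]2(O)CO)cc1F`: 4.1 L/kg
- compound 3, `N#Cc1ccc(O[C@H]2CN(S(=O)(=O)c3ccc(Cl)cn3)C[C@@]2(O)CO)cc1F`: 2.2 L/kg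

Compound 3 stands lowest of the three numbers. The step of a 2.7-fold lower number from compound 1 to compound 3 (0.44 log units; beyond the scatter) is beyond the scatter; the step of a 1.9-fold lower number from compound 2 to compound 3 (0.27 log units; within the scatter) is within the scatter, so compounds 2 and 3 cannot be ordered. The step of a 1.5-fold lower number from compound 1 to compound 2 (0.17 log units; within the scatter) is likewise within the scatter. Every measured step alters only the group on the sulfonyl sulfur.

Compound 4, `N#Cc1ccc(O[C@H]2CN(S(=O)(=O)c3ccc(Cl)cn3)C[C@@]2(O)CN)cc1F`, is the next entry. It differs from compound 3 as amino in place of hydroxy on a saturated chain carbon bound to a saturated ring carbon. Within the data shown here, none of the measured steps touches this end of the core, so no step bears directly on the change, and the expectation rests on compound 3 alone, with a wide margin. The step of a 1.6-fold higher number from compound 3 to compound 4 (0.20 log units; within the scatter) is therefore expected to be small, though a move in either direction beyond the scatter cannot be excluded. Compound 4 is expected to give 3.5 L/kg in this assay, with a range from 1.3 L/kg to 10 L/kg.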

Compound 4, volume of distribution at steady state: 6.7 L/kg
The estimate for compound 4 lay 1.9-fold (0.28 log units) below the measured number; the range from low to high includes it.
By their numbers in this assay, from the lowest: compounds 3, 2, 1 and 4 (each within the scatter of the next, the first and the last beyond it).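

In this assay the change from hydroxymethyl to aminomethyl gives a 3.0-fold higher number from compound 3 to compound 4 (0.48 log units; beyond the scatter) and is the only step shown outside the group on the sulfonyl sulfur, so this end of the shared core can also move the read-out beyond the scatter. The exchange replaces one oxygen with one nitrogen and leaves the counted hydrogen-bond donors and acceptors unchanged, so those counts do not separate the two compounds. No measurement at hand accounts for the step.

Whether the step carries over to the other sulfonyl groups remains open, as this change is shown only with 5-chloropyridin-2-yl on the sulfonyl sulfur. Also open, as far as these compounds go, is how a methylaminomethyl group, a carboxylic acid or a longer chain such as aminoethyl would read at this place.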